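The source may hold more compounds than are shown below. What is called first, only, known or untested is meant among the compounds shown, and "the series" means these compounds.

The measured compounds, with their numbers in an assay for inhibition of Indoleamine 2,3-dioxygenase 1 (Homo sapiens), read by spectrophotometry, with stated times of 1 h and 4 h; on this read-out lower numbers stand for stronger inhibition and higher numbers for weaker inhibition:

Compound 1, `CC(=O)Nc1ccc(S(=O)(=O)NNc2ccc(Cl)cc2)cc1`, gives 155 nM.
Compound 2, `CC(=O)Nc1ccc(S(=O)(=O)NNc2ccc(Br)cc2)cc1`, gives 130 nM.
Compound 3, `CC(=O)Nc1ccc(S(=O)(=O)NNc2ccc(Br)c(F)c2)cc1`, gives 205 nM.

On these figures compound 3 carries the largest number of the three, yet its distance to the others is small: compound 1 lies nearest and compound 2 furthest, and both gaps fall inside the usual scatter of repeated measurements, so the three compounds cannot be told apart on this basis.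

Compound 4, `CC(=O)Nc1ccc(S(=O)(=O)NNc2ccc(Cl)c(F)c2)cc1`, has not been measured. From compound 3 to compound 4 the change is chloro in place of bromo on an aromatic carbon. Within the data shown here, the only measured step that involves the same exchange is the one from compound 1 to compound 2, which ran in the opposite direction and gave a 1.2-fold lower number from compound 1 to compound 2 (0.08 log units; within the scatter). The step from compound 2 to compound 3 gave a 1.6-fold higher number from compound 2 to compound 3 (0.20 log units; within the scatter); it added the fluoro group that compound 4 keeps, so it does not bear on the chloro-for-bromo swap itself. Reversing the small step seen between compound 1 and compound 2, compound 4 is expected to shift by a 1.2-fold higher number from compound 3 to compound 4 (0.08 log units; within the scatter) in this assay, a shift that stays within the scatter. The estimate for compound 4 is 245 nM, with a range from 130 nM to 460 nM.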

Compound 4, half-maximal inhibitory concentration: 194 nM
For compound 4 the middle estimate is 1.3-fold (0.10 log units) above the measured one, within the range that was stated.
By their numbers in this assay, from the lowest: compounds 2, 1, 4 and 3 (each within the scatter of the next).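

With the fluoro group present, chloro in place of bromo gives a 1.1-fold lower number from compound 3 to compound 4 (0.02 log units; within the scatter) in this assay, so this exchange can now be read on two cores, with and without the fluoro group: the same change on two cores in this assay, a 1.2-fold lower number (0.08 log units; within the scatter) from compound 1 to compound 2 and a 1.1-fold higher number (0.02 log units; within the scatter) from compound 4 to compound 3, 1.3-fold (0.10 log units) apart, within the scatter of two such steps

The fluoro group can also be read a second time, because adding it to the chloro compound gives a 1.3-fold higher number from compound 1 to compound 4 (0.10 log units; within the scatter), and this step can be set against the one seen with bromo: the same change on two cores in this assay, a 1.6-fold higher number (0.20 log units; within the scatter) from compound 2 to compound 3 and a 1.3-fold higher number (0.10 log units; within the scatter) from compound 1 to compound 4, 1.3-fold (0.10 log units) apart, within the scatter of two such steps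

Taken together, these compounds show no sign that the choice between chloro and bromo at this position depends on the fluoro group, or that the effect of the fluoro group depends on that choice, though all of these steps are small enough to lie within the scatter.

Since only these two halogens appear at this position, the compounds shown leave open whether a group of another kind there, such as an amine, a nitrile or a carboxylic acid, would also leave the number within the scatter. They also leave open how a methyl group in place of the fluoro group would read in this assay.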